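A few compounds are considered here, and "the series" means these few. Any claim that something is new, unique, unknown or untested is made for them only; others in the source may bear on it.

Measured in a functional assay on COLO 205 cells (Homo sapiens) for antiproliferative activity, read by sulforhodamine B assay, with a stated time of 72 h; on this read-out lower numbers stand for stronger inhibition and higher numbers for weaker inhibition:
- compound 1 `O=S(=O)(Nc1ncccn1)c1ccc(Nc2nncc3ccccc23)cc1`: 43 nM
- compound 2 `Cc1cc(NS(=O)(=O)c2ccc(Nc3nncc4ccccc34)cc2)no1`: 43 nM

The two compounds share a core and differ only in the group on the sulfonamide nitrogen. Among the measured compounds shown here, compound 2 stands level with its only neighbour, at 43 nM, and the step between them reads no change at the digits printed from compound 1 to compound 2 (within the scatter). That step lies within the scatter.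

Compound 3 `NS(=O)(=O)c1ccc(Nc2nncc3ccccc23)cc1` has not yet been measured in this assay. It takes the series one move further, with hydrogen in place of 5-methyl-1,2-oxazol-3-yl on a sulfonamide nitrogen.

For the measured compounds named here, the single measured step, no change at the digits printed from compound 1 to compound 2 (within the scatter), bears on this position, but it exchanges one ring-bearing group for another. It says nothing direct about removing the ring altogether, so it offers only weak guidance. A flat result may carry over, yet a loss is more plausible than a gain, and the data cannot settle this. The expected change is modest and toward weaker inhibition, estimated as a 2.3-fold higher number from compound 2 to compound 3 (0.37 log units; beyond the scatter). Compound 3 is estimated at 100 nM, with an expected range of 20 nM to 700 nM.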

Compound 3, half-maximal inhibitory concentration: 23 nM
For compound 3 the middle estimate is 4.3-fold (0.64 log units) above the measured one, and the stated range covers the measured number.
By their numbers in this assay, from the lowest: compounds 3, 1 and 2 (each within the scatter of the next).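

In this assay, the sulfonamide nitrogen keeps its level without any ring-bearing group: hydrogen in place of 5-methyl-1,2-oxazol-3-yl gives (a 1.9-fold lower number from compound 2 to compound 3 (0.27 log units; within the scatter)), and hydrogen in place of pyrimidin-2-yl gives (a 1.9-fold lower number from compound 1 to compound 3 (0.27 log units; within the scatter)). Among the compounds shown here, the earlier pair showed only that one ring-bearing group could stand in for another, whereas these two steps show that the same level is reached when the ring is gone and the nitrogen carries only hydrogen, so that neither of the two rings is required for this read-out. No information is available on what lies behind the close grouping of the three compounds.

What the compounds shown leave open is whether a small group on that nitrogen, such as methyl or acetyl, or a longer chain ending in an amine or a carboxylic acid, would stay at this level as well. They also leave open whether the same picture holds on the shared core once that core itself is altered, or in cells other than those of this single read-out.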